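A few compounds are considered here, and "the series" means these few. Any claim that something is new, unique, unknown or untested is made for them only; others in the source may bear on it.

Measured compounds in an ADME assay on cells (Hepatocyte, Rattus norvegicus) for metabolic stability; a higher number here means faster removal of the compound, a lower number slower removal:
Compound 1 `CNC(=O)CN1CCC(c2cc3c(-c4ccc(=O)n(C(C)C)c4)ccnc3[nH]2)CC1` — 8.9 uL/min
Compound 2 `COc1cc(F)ccc1-c1ccnc2[nH]c(C3CCN(CC(=O)N(C)C)CC3)cc12` — 38 uL/min
Compound 3 `CC(C)Cn1cc(-c2ccnc3[nH]c(C4CCN(CC(=O)N(C)C)CC4)cc23)ccc1=O` — 6.6 uL/min

Among these three, compound 1 has the second highest number. Its nearest neighbour is compound 3, whose value lies within the usual scatter of compound 1, so the two cannot be told apart on this assay. Compound 2 stands clearly apart, with a number beyond the scatter above that of compound 1.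

Compound 4 `CC(C)n1cc(-c2ccnc3[nH]c(C4CCN(CC(=O)N5CCCCC5)CC4)cc23)ccc1=O` is not yet measured. It differs from compound 1 in one place: piperidin-1-yl in place of methylamino on a carbonyl carbon. Among the measured compounds shown here, no measured pair in this set shows that exact change, so its effect can only be judged against the spread already seen, which runs from compound 3 up to compound 2.

The expectation for compound 4 is a step of a 1.6-fold higher number from compound 1 to compound 4 (0.20 log units; within the scatter) from compound 1, a modest move upward that may or may not exceed the scatter. The estimated value for compound 4 is 14 uL/min, with a range from 6 uL/min to 35 uL/min.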

Compound 4, intrinsic clearance in a liver preparation (reported as CLH), per the amount of preparation that the assay uses: 26 uL/min
Compound 4: middle estimate off by 1.9-fold (0.27 log units), on the low side; the range from low to high includes it.
By their numbers in this assay, from the lowest: compounds 3 and 1 (each within the scatter of the next); then compounds 4 and 2 (each within the scatter of the next).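

In this assay, piperidin-1-yl in place of methylamino on the carbonyl carbon gives a 2.9-fold higher number from compound 1 to compound 4 (0.47 log units; beyond the scatter) and so lies beyond the usual scatter. Among the compounds shown here, this is the first one-place comparison in the set, and it shows that the group on this carbonyl carbon is not silent: with the rest of the structure unchanged, the swap goes with faster removal. No measurement at hand gives a cause for this rise.

The pair cannot separate the loss of the amide hydrogen from the gain of the six-membered ring, since both change together in this one step. A smaller ring such as pyrrolidin-1-yl, or a ring with a second hetero atom such as morpholin-4-yl, on the same carbonyl carbon would bear on that open question.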